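This account rests on a few compounds, and the source may have more. Where it says the series, first, only, none or still open, it means among the compounds named here.

In a functional assay on MDA-MB-435 cells (Homo sapiens) for cytotoxicity, read by MTT assay, with a stated time of 72 h (on this read-out higher numbers stand for weaker inhibition and lower numbers for stronger inhibition), compound 2 `NCCNc1c(C(=O)NCc2ccc(F)cc2)nc(Br)c2cccnc12` gives 12000 nM. Compound 3 `N[C@H]1CC[C@H](NC(=O)c2nc(Br)c3cccnc3c2NCc2ccc(F)cc2)CC1` gives 6600 nM in this assay, and the two numbers sit within the usual scatter of each other, so compound 2 holds the higher of the two numbers shown without the gap to compound 3 meaning a real difference. Compound 1 `C[C@@H](CO)Nc1nc(C(=O)NCc2ccc(F)cc2)c(O)c2ncccc12` reaches only a limit of this assay, > 20000 nM, which is the limit of > 20000 nM in this assay, at which 1 of the 3 values shown sits.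

Compound 4 `Cc1ccc(S(=O)(=O)Oc2c(C(=O)NCc3ccc(F)cc3)nc(Br)c3cccnc23)cc1` has not yet been measured in this assay. It differs from compound 2 in one place: ((4-methylphenyl)sulfonyl)oxy in place of (2-aminoethyl)amino on an aromatic carbon. Among the measured compounds shown here, no step between two measured compounds tracks such a change, so the expectation rests on the weak numbers of compounds 2 and 3 alone. With the (2-aminoethyl)amino group gone and a ((4-methylphenyl)sulfonyl)oxy group entering, the author expects no step beyond the scatter, and estimates the step of no change at the digits printed from compound 2 to compound 4 (within the scatter). Compound 4 is expected to give about 12000 nM in this assay, within a range from 3500 nM to 40000 nM.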

Compound 4, half-maximal inhibitory concentration: > 20000 nM
Compound 4 was reported as a limit; the forecaster's own chance of this, stated with the estimate: 35%; middle value at least 1.6-fold (0.22 log units) away from the limit.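

In this assay, putting ((4-methylphenyl)sulfonyl)oxy in place of (2-aminoethyl)amino on this aromatic carbon, para to a bromo group, gives an at least 1.6-fold higher number from compound 2 to compound 4 (0.22 log units; that floor lies within the scatter). Among the compounds shown here, this is the first step read at this position, and it shows that the larger group, with its aromatic ring and no hydrogen-bond donors, brings no gain in this assay, though the true size of the step cannot be read. Compound 4 is reported as a limit and not as a number, and it is the second such value in the series: the limit of > 20000 nM in this assay, at which 2 of the 4 values shown sit.

The swap removes the amine and adds the sulfonyloxy group in one step, so the compounds shown do not separate the two changes. Also open, from the compounds shown here alone, is whether a methoxy group or a longer aminoalkyl chain on this carbon would move the number beyond the scatter from compound 2.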